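The compounds below may be only part of what the source reports. "The series", "measured", "known", "first", "only" and "open" are said of these compounds alone.

Measured so far in a functional assay on the whole organism with Mus musculus as the target, in the rotarod test; on this read-out higher numbers stand for an effect only at larger amounts of compound and lower numbers for an effect already at smaller amounts:

- compound 1 `CC(=O)NCC(=O)N(C)c1ccc(Cl)cc1C(=O)c1ccccc1Cl` gives 58 mg/kg
- compound 2 `CCC(=O)NCC(=O)N(C)c1ccc(Cl)cc1C(=O)c1ccccc1Cl` gives 36 mg/kg

Not yet measured:

- compound 3 `CN(C)CC(=O)NCC(=O)N(C)c1ccc(Cl)cc1C(=O)c1ccccc1Cl`

With only these two numbers, compound 2 has no clear rank, since its value cannot be told apart from that of compound 1. Within the data shown here, the one measured step is a 1.6-fold lower number from compound 1 to compound 2 (0.21 log units; within the scatter), and it is a methyl in place of hydrogen on a saturated chain carbon bound to a carbonyl carbon.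

Compound 3 differs from compound 2 in one place: dimethylamino in place of methyl on a saturated chain carbon bound to a carbonyl carbon. Put simply, this is dimethylamino in place of methyl on a saturated chain carbon bound to a carbonyl carbon. Among the measured compounds shown here, the measured step concerns a carbon described in the same words, so it is the only guide, but it adds just a methyl. For the measured compounds named here, no measured compound carries dimethylamino, so the data say little about this larger change. No shift beyond the scatter is expected, and the expected step is a 1.3-fold higher number from compound 2 to compound 3 (0.10 log units; within the scatter). For compound 3 the estimated value is 45 mg/kg, with an expected range from 14 mg/kg to 140 mg/kg, kept wide for that reason.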

Compound 3, dose for half-maximal effect: 26 mg/kg
Compound 3: the middle estimate sits 1.7-fold (0.24 log units) above what was measured; low and high end bracket the measured number.
By their numbers in this assay, from the lowest: compounds 3, 2 and 1 (each within the scatter of the next, the first and the last beyond it).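

In this assay, putting dimethylamino in place of methyl on a saturated chain carbon bound to a carbonyl carbon gives a 1.4-fold lower number from compound 2 to compound 3 (0.14 log units; within the scatter), so compound 2 and compound 3 cannot be told apart even though the entering group has 3 heavy atoms, including a nitrogen, and 1 hydrogen-bond acceptor. This shows that the position accepts a larger group containing nitrogen without a change beyond the scatter, something the addition of a methyl could not show. Against the hydrogen of compound 1, the same place shows a 2.2-fold lower number from compound 1 to compound 3 (0.35 log units; beyond the scatter), the first step in this short series to pass beyond the scatter, although only modestly, and nothing available explains why the numbers fall as they do.

The compounds shown leave open whether the nitrogen matters or whether a carbon group such as isopropyl would read the same in this place. They also leave open how a ring amine such as morpholine or piperidine, or a carboxylic acid, would behave at this position in this assay.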